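The source may report more compounds than this note shows. Statements on the series, on what has been measured and on what is new or still open speak of the compounds shown alone.

Compound 1 `N#Cc1c(-c2nnc(-c3ccccc3)c3nn(-c4ccccc4)cc23)nn(-c2ccccc2)c1-c1ccccc1`: > 100000 nM (a limit of the assay, not a number)
Compound 2 `N#Cc1c(-c2nnc(-c3ccccc3)c3nn(-c4ccc(Cl)cc4)cc23)nn(-c2ccccc2)c1-c1ccccc1`: 8940 nM

Among the measured compounds shown here, in a functional assay on OVCAR-5 cells (Homo sapiens) for inhibition, read by sulforhodamine B assay, with a stated time of 48 h (on this read-out higher numbers stand for weaker inhibition of growth and lower numbers for stronger inhibition of growth), compound 2 gives 8940 nM, the only true number so far. Compound 1 stands at > 100000 nM, which is a limit. Compound 3 `Cc1ccc(-n2cc3c(-c4nn(-c5ccccc5)c(-c5ccccc5)c4C#N)nnc(-c4ccccc4)c3n2)cc1` differs from compound 2 as follows: methyl in place of chloro on an aromatic carbon. In words, this is methyl in place of chloro on an aromatic carbon. For the measured compounds named here, no measured step involves methyl. Going by the values given here, the only guide is an at least 11-fold lower number from compound 1 to compound 2 (1.04 log units; beyond the scatter), a large step that came with chloro in place of hydrogen on that same carbon. With chloro gone again, a higher number is expected in this assay, of moderate size and quite uncertain. The expected change is a 1.7-fold higher number from compound 2 to compound 3 (0.22 log units; within the scatter). For compound 3 the estimated value is 15000 nM, with an expected range of 3000 nM to 80000 nM.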

Compound 3, concentration for 50% growth inhibition: 7940 nM
Estimate against measurement, compound 3: 1.9-fold (0.28 log units) above; the range from low to high includes it.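

In this assay, methyl and chloro on this carbon, para to a large group, cannot be told apart: the change gives a 1.1-fold lower number from compound 2 to compound 3 (0.05 log units; within the scatter). Methyl in place of hydrogen gives an at least 12-fold lower number from compound 1 to compound 3 (1.10 log units; beyond the scatter), so among these three compounds the large drop in the number is not tied to chloro alone, since both 4-chlorophenyl and 4-methylphenyl stand well apart from the unsubstituted ring of compound 1. The true size of that step stays unknown, because compound 1 rests on a limit of the assay and not a number: the limit of > 100000 nM in this assay, at which 1 of the 3 values shown sits.

On these data alone, how an amine, a carboxylic acid or a longer chain such as butyl would read on this same carbon remains open. So does whether any such group could bring the number far lower than chloro and methyl do.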